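A few compounds are considered here, and "the series" means these few. Any claim that something is new, unique, unknown or untested is made for them only; others in the source may bear on it.

Measured compounds and their values:
Compound 1, `C=CC1=C(C(=O)NCCC)C(c2ccc(F)cc2)OC1`, in a functional assay on HeLa cells (Homo sapiens) for cytotoxicity, read by MTT assay, with a stated time of 24 h (on this read-out higher numbers stand for weaker inhibition and lower numbers for stronger inhibition), gives > 100000 nM, which is a limit of the assay and not a number.
Compound 2, `C=CC1=C(C(=O)Nc2ccc(OCC)cc2)C(c2ccc(OC)cc2)OC1`, in this assay gives > 100000 nM, again a limit.
Compound 3, `C=CC1=C(C(=O)NCc2ccc(Cl)cc2)C(c2ccc(OC)cc2)OC1`, in this assay gives > 100000 nM, also a limit.

Compound 3 therefore stands nowhere in particular on a scale of numbers: it sits at the limit of > 100000 nM in this assay, at which 3 of the 3 values shown sit, and so do the two compounds beside it. Among the measured compounds shown here, the single step between measured compounds, a step that the two limits leave unreadable from compound 2 to compound 3, cannot be sized for that reason.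

Compound 4, `C=CC1=C(C(=O)NCCC)C(c2ccc(OC)cc2)OC1`, differs from compound 3 by ethyl in place of 4-chlorophenyl on a saturated chain carbon bound to an amide-type nitrogen. The measured steps bear on this change only weakly. Compound 1 already carries the same propyl amide as compound 4, differing from it only in the aryl group on the shared core, and it gives a limit. Compound 2 and compound 3 show that swapping one amide substituent for another left both at the limit. Nothing among these compounds points to a readable number appearing.

The expected step from compound 3 to compound 4 is thus a step that the limit leaves unreadable from compound 3 to compound 4, which means no step beyond the scatter. Compound 4 is expected to give 150000 nM, within a range from 50000 nM to 500000 nM, most likely reported again as a limit.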

Compound 4, half-maximal inhibitory concentration: 14000 nM
Estimate against measurement, compound 4: 11-fold (1.03 log units) above; measured number below the stated range.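

Within the compounds carrying the methoxy group, propyl in place of 4-chlorobenzyl on the amide-type nitrogen gives an at least 7.1-fold lower number from compound 3 to compound 4 (0.85 log units; beyond the scatter) in this assay, and propyl in place of 4-ethoxyphenyl gives an at least 7.1-fold lower number from compound 2 to compound 4 (0.85 log units; beyond the scatter), so the group on this nitrogen can decide whether a readable number appears at all. Propyl is not enough by itself, since methoxy in place of fluoro on an aromatic carbon, with the propyl amide kept, gives an at least 7.1-fold lower number from compound 1 to compound 4 (0.85 log units; beyond the scatter): among these compounds a readable number comes only with propyl and methoxy together, while compound 1 has propyl without methoxy and compound 2 and compound 3 have methoxy without propyl. The one step among the earlier compounds cannot be read, and each of those compounds gives only a limit of the assay, not a number: the limit of > 100000 nM in this assay, at which 3 of the 4 values shown sit.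

On these data alone, the true sizes of these steps stay open, as each starts from a limit and could be larger than printed. As far as these compounds go, it is also open whether a shorter ethyl chain, a longer butyl chain or a propyl chain ending in an amine or a carboxylic acid would lower the number further or return it to the limit.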